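Replacing pyridin-4-yl with (azetidin-1-yl)methyl on the shared core

The source may hold more compounds than are shown below. What is called first, only, known or untested is meant among the compounds shown, and "the series" means these compounds.

Compound 1 `O=C1NC(=O)c2c1c1c3ccc(CN4CCNCC4)cc3[nH]c1c1c2c2cccc3c2n1CCC3` reads > 10000 nM in a functional assay on HCT-116 cells (Homo sapiens) for cytotoxicity (on this read-out higher numbers stand for weaker inhibition and lower numbers for stronger inhibition), and this is a limit of the assay. Among the compounds with values here, compound 2 `O=C1NC(=O)c2c1c1c3ccc(-c4ccncc4)cc3[nH]c1c1c2c2cccc3c2n1CCC3` gives 3290 nM in this assay, the only actual number so far. Compound 3 `O=C1NC(=O)c2c1c1c3ccc(CN4CCC4)cc3[nH]c1c1c2c2cccc3c2n1CCC3` differs from compound 2 by (azetidin-1-yl)methyl in place of pyridin-4-yl on an aromatic carbon, with (azetidin-1-yl)methyl in place of pyridin-4-yl on an aromatic carbon. Within the data shown here, the only measured step bearing on this is an at least 3.0-fold lower number from compound 1 to compound 2 (0.48 log units; beyond the scatter), and it starts from the limit of > 10000 nM in this assay, at which 1 of the 2 values shown sits. That step ran the opposite way, with (piperazin-1-yl)methyl leaving, so a modest rise is expected. The expected change is a 2.1-fold higher number from compound 2 to compound 3 (0.33 log units; beyond the scatter). The estimate for compound 3 is 7000 nM, within a range of 2000 nM to 20000 nM.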

Compound 3, half-maximal inhibitory concentration: 230 nM
Estimate against measurement, compound 3: 30-fold (1.48 log units) above, and the stated range ends above it.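

Within the data shown here, at this aromatic carbon, (azetidin-1-yl)methyl gives the lowest number so far in this assay, with a 14-fold lower number from compound 2 to compound 3 (1.16 log units; beyond the scatter), so an aromatic pyridin-4-yl is not needed here for a low number. The ring on the saturated chain carbon also matters, as azetidin-1-yl in place of piperazin-1-yl gives an at least 43-fold lower number from compound 1 to compound 3 (1.63 log units; beyond the scatter). That step starts from compound 1, whose value is a limit and not a number: the limit of > 10000 nM in this assay, at which 1 of the 3 values shown sits.

Going by these compounds, it remains open whether a pyrrolidin-1-yl or dimethylamino group on the same methyl would give a similar number. On these data alone, whether a longer chain to the azetidine would keep it is also open.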